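Swapping a Pyrimidine for a Trifluoromethylphenyl Ring

A few compounds are considered here, and "the series" means these few. Any claim that something is new, unique, unknown or untested is made for them only; others in the source may bear on it.

Compound 1 `O=C1c2ccccc2S(=O)(=O)N1CCCCCN1CCN(c2ncccn2)CC1` is the weaker of two compounds tested in an assay on HEK293 cells for displacement of a labelled ligand from 5-hydroxytryptamine receptor 6 (Homo sapiens); a lower number here means a stronger inhibitor, a higher number a weaker inhibitor: in this assay compound 1 gives 7100 nM. Compound 2 `O=C1c2ccccc2S(=O)(=O)N1CCCCCCN1CCN(c2ccc(Cl)cc2)CC1` differs from compound 1 in several places. In this assay compound 2 gives 72 nM, a far lower number that lies well beyond the usual scatter. Compound 3 `O=C1c2ccccc2S(=O)(=O)N1CCCCCN1CCN(c2cccc(C(F)(F)F)c2)CC1` has not yet been measured. It differs from compound 1 by a single change: 3-(trifluoromethyl)phenyl in place of pyrimidin-2-yl on an amine nitrogen in a ring. For the measured compounds named here, with no directly comparable pair measured, the size of this step is an estimate rather than a known quantity. Going by the values given here, since compound 2, the only measured compound carrying a carbon-only aromatic ring on that ring nitrogen, gives 72 nM, compound 3 is expected to move in the same direction, with an estimated step of a 24-fold lower number from compound 1 to compound 3 (1.37 log units; beyond the scatter). Compound 3 is therefore estimated to give 300 nM in this assay, likely between 60 nM and 1500 nM.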

Compound 3, inhibition constant: 1350 nM
Estimate against measurement, compound 3: 4.5-fold (0.65 log units) below; measured number inside the range.
By their numbers in this assay, from the lowest: compound 2; then compound 3; then compound 1.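

In this assay, for the compounds shown here, replacing pyrimidin-2-yl with 3-(trifluoromethyl)phenyl on the ring nitrogen gives a 5.3-fold lower number from compound 1 to compound 3 (0.72 log units; beyond the scatter), the first reading of this position with the rest of the molecule unchanged. The group on this nitrogen therefore changes the number by itself, although the step is modest. The swap removes 2 hydrogen-bond acceptors and raises the group from 6 to 10 heavy atoms, but no measurement here explains the step.

The compounds shown leave open how much of the step goes with losing the ring nitrogens and how much with adding the trifluoromethyl group, a split that a plain phenyl ring on the same nitrogen would help to resolve. They also leave open how a methoxy group would read in place of the trifluoromethyl group.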